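A Difluoroethyl Step from Compound 2 to Compound 3

A few compounds are considered here, and "the series" means these few. Any claim that something is new, unique, unknown or untested is made for them only; others in the source may bear on it.

Compound 2 `CCc1ncncc1-c1nc2cc(F)c(F)cc2n1C1CC1` was tested in an ADME assay on cells for inhibition of cytochrome P450 11B1, mitochondrial (Homo sapiens), read by HPLC, with a stated time of 60 min (on this read-out lower numbers stand for stronger inhibition and higher numbers for weaker inhibition), and gave 3330 nM. Within the data shown here, it is one of only two numbers so far; the other belongs to compound 1 `Fc1cc2nc(-c3cncnc3)n(C3CC3)c2cc1F`, which gave 2270 nM, a difference of a 1.5-fold higher number from compound 1 to compound 2 (0.17 log units; within the scatter). Compound 3 `CC(F)(F)c1ncncc1-c1nc2cc(F)c(F)cc2n1C1CC1` is not yet measured; it differs from compound 2 as follows: 1,1-difluoroethyl in place of ethyl on an aromatic carbon. Among the measured compounds shown here, the only step at this place, a 1.5-fold higher number from compound 1 to compound 2 (0.17 log units; within the scatter), lay within the scatter, and no other step bears on the change, so no shift beyond the scatter is expected in this assay. Compound 3 is therefore estimated at 3000 nM, between 1200 nM and 8000 nM. That estimate means a step of a 1.1-fold lower number from compound 2 to compound 3 (0.05 log units; within the scatter).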

Compound 3, half-maximal inhibitory concentration: 5720 nM
Compound 3: middle estimate off by 1.9-fold (0.28 log units), on the low side, and the stated range covers the measured number.
By their numbers in this assay, from the lowest: compounds 1, 2 and 3 (each within the scatter of the next, the first and the last beyond it).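

In this assay the exchange of ethyl for 1,1-difluoroethyl at this position gave a 1.7-fold higher number from compound 2 to compound 3 (0.23 log units; within the scatter) and so does not separate the two groups. Among these compounds, measured against hydrogen, 1,1-difluoroethyl gave a 2.5-fold higher number from compound 1 to compound 3 (0.40 log units; beyond the scatter) and thus the first step at this position to pass the scatter, a modest one toward weaker inhibition. Nothing at hand accounts for that step. The compounds leave open how this position would respond to an amine, a methoxy group or a longer chain such as propyl. They also leave open whether a carboxylic acid here would move the number further.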